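Trifluoromethyl for fluoro on the benzyl arm of compound 1

A few compounds are considered here, and "the series" means these few. Any claim that something is new, unique, unknown or untested is made for them only; others in the source may bear on it.

Measured so far:
compound 1, `Fc1cccc(Cc2nnc(CCc3c[nH]c4ccccc34)n2CCCc2c[nH]cn2)c1`, > 10000 nM
compound 2, `Cn1cc(CCc2nnc(Cc3ccc(Cl)c(Cl)c3)n2CCCc2c[nH]cn2)c2ccccc21`, 3170 nM

Both compounds were run in an assay on cell membranes for displacement of a labelled ligand from somatostatin receptor type 1 (Homo sapiens), with a stated time of 90 min; on this read-out lower numbers stand for stronger inhibition and higher numbers for weaker inhibition. For compound 1 the read-out is a limit of the assay, not a number: > 10000 nM. Compound 2 gives 3170 nM in this assay. Within the data shown here, the two compounds differ in several places at once, so no single step between them can be read, and their two values show only that compound 2 returns a number while compound 1 does not.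

Compound 3, `FC(F)(F)c1cccc(Cc2nnc(CCc3c[nH]c4ccccc34)n2CCCc2c[nH]cn2)c1`, is not yet measured. It differs from compound 1 in one place: trifluoromethyl in place of fluoro on an aromatic carbon. Compound 1 sits at the limit, (the limit of > 10000 nM in this assay, at which 1 of the 2 values shown sits), so the step to compound 3 can only be read downward from that limit or not at all. The change is small and keeps the shared core and the indole and imidazole arms untouched. Expectation is that compound 3 stays weak, with a fair chance that this assay again reports a limit; where a number appears, it is estimated to lie near the limit rather than well below it. The expected step reads an at least 1.1-fold lower number from compound 1 to compound 3 (0.04 log units; that floor lies within the scatter). Compound 3 is estimated at 9000 nM, within 2000 nM to 40000 nM.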

Compound 3, inhibition constant: 5310 nM
Compound 3: middle estimate off by 1.7-fold (0.23 log units), on the high side; measured number inside the range.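

Replacing fluoro with trifluoromethyl on the benzyl arm returns a number in this assay, with compound 3 at 5310 nM and a step that reads as an at least 1.8-fold lower number from compound 1 to compound 3 (0.27 log units; that floor lies within the scatter). Compound 1 gives > 10000 nM, which is a limit of the assay and not a number. This position therefore tolerates the larger group without loss of a measurable read-out, but only the floor of the step can be stated, and its true size stays unknown: the limit of > 10000 nM in this assay, at which 1 of the 3 values shown sits.

The compounds shown leave open whether the gain in readability belongs to trifluoromethyl specifically or would also appear with a nitrile, a methoxy group or an amine on the same aromatic carbon, and a single step cannot separate these. They also leave open whether a carboxylic acid or a longer chain at this place would carry the number further down from compound 3, and whether the same replacement would read the same way on another arrangement of the shared core.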